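Ethynyl in place of thiophen-2-yl: compound 3 to compound 4

The compounds below may be only part of what the source reports. "The series", "measured", "known", "first", "only" and "open" are said of these compounds alone.

Measured in a functional assay on HCT-116 cells (Homo sapiens), read by MTT assay, with a stated time of 72 h; a higher number here means a weaker inhibitor, a lower number a stronger inhibitor:
- compound 1 `COc1ncnc2c1c(-c1ccccc1)cn2[C@@H]1O[C@H](CO)[C@@H](O)[C@H]1O` gives > 20000 nM (a limit)
- compound 2 `C#Cc1cn([C@@H]2O[C@H](CO)[C@@H](O)[C@H]2O)c2ncnc(OC)c12` gives 4060 nM (a number)
- compound 3 `CSc1ncnc2c1c(-c1cccs1)cn2[C@@H]1O[C@H](CO)[C@@H](O)[C@H]1O` gives > 20000 nM (a limit)

Compound 3 stands at > 20000 nM here, which is a limit of the assay and not a number. That limit is not unique to it: the limit of > 20000 nM in this assay, at which 2 of the 3 values shown sit, so the low end of the series is not resolved.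

Compound 4 `C#Cc1cn([C@@H]2O[C@H](CO)[C@@H](O)[C@H]2O)c2ncnc(SC)c12` carries ethynyl in place of thiophen-2-yl on an aromatic carbon, with the rest of compound 3 unchanged.

Among the compounds with values here, one measured step bears on this change: an at least 4.9-fold lower number from compound 1 to compound 2 (0.69 log units; beyond the scatter), also ethynyl replacing a ring on an aromatic carbon. The transfer is imperfect, since the core of compound 1 differs from that of compound 3 and the leaving ring is phenyl rather than thiophen-2-yl. Compound 2 at 4060 nM remains the only ethynyl reference with a number.

A step of similar size toward a lower number is therefore expected, estimated as an at least 5.0-fold lower number from compound 3 to compound 4 (0.69 log units; beyond the scatter) in this assay at this stage. For compound 4 the estimate is 4000 nM, with an expected range of 1000 nM to 16000 nM in this reading.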

Compound 4, half-maximal inhibitory concentration: 30 nM
For compound 4 the middle estimate is 130-fold (2.12 log units) above the measured one, outside the stated range (below it).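

In this assay, ethynyl on this aromatic carbon of the five-membered ring gives an at least 660-fold lower number from compound 3 to compound 4 (2.82 log units; beyond the scatter), so the direction seen in the methoxy pair also holds with methylsulfanyl on the shared core. The size of this step is only a floor, since compound 3 stands at a limit of the assay and not at a number: the limit of > 20000 nM in this assay, at which 2 of the 4 values shown sit.

Within the data shown here, with ethynyl held fixed, the group on the other ring also changes the read-out strongly, as methylsulfanyl in place of methoxy gives a 140-fold lower number from compound 2 to compound 4 (2.13 log units; beyond the scatter), a kind of step that the earlier compounds did not offer and one that is measured between two numbers.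

On these data alone, how narrow the demand is at the ethynyl position remains open: a nitrile, an ethyl group or a bromine atom on the same carbon would show whether the triple bond itself counts or whether simply a group smaller than the rings is enough. Equally open, as far as these compounds go, is how far the methylsulfanyl result extends, for instance to a longer ethylsulfanyl chain or to an amine in the same place.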